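A few compounds are considered here, and "the series" means these few. Any claim that something is new, unique, unknown or untested is made for them only; others in the source may bear on it.

Compound 2, with the structure `Cc1ccc(C(=O)N2N=C(c3cc4ccccc4oc3=O)CC2c2ccccc2)cc1`, was tested in a functional assay on PC-3 cells (Homo sapiens) for cytotoxicity, read by MTT assay, with a stated time of 48 h (on this read-out higher numbers stand for weaker inhibition and lower numbers for stronger inhibition), where compound 2 gives 13200 nM. That is the lower of the two numbers recorded so far. The other measured compound, compound 1, has the structure `CC1=NN(C(=O)CN2CCC(Cl)CC2)C(c2ccccc2O)C1`; in this assay compound 1 gives 34800 nM, a number that stands above that of compound 2 by more than the usual scatter. Since the two structures differ in more than one place, nothing beyond these two values can be read from the pair.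

The next compound, compound 3, has the structure `CCCNCC(=O)N1N=C(c2cc3ccccc3oc2=O)CC1c1ccccc1`. It differs from compound 2 in a single place: (propylamino)methyl in place of 4-methylphenyl on a carbonyl carbon. For the measured compounds named here, no measured pair in this set shows the effect of such a change, so there is no step to lean on. Going by the values given here, the account therefore rests on the single value of compound 2 alone. On that basis compound 3 is expected to land near compound 2, with a step from compound 2 to compound 3 of a 1.5-fold higher number from compound 2 to compound 3 (0.18 log units; within the scatter), likely within or just beyond the scatter. The estimate for compound 3 in this assay is 20000 nM, with a range from 6000 nM to 70000 nM.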

Compound 3, half-maximal inhibitory concentration: 7270 nM
Estimate against measurement, compound 3: 2.8-fold (0.44 log units) above, within the range that was stated.
By their numbers in this assay, from the lowest: compounds 3 and 2 (each within the scatter of the next); then compound 1.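

Replacing 4-methylphenyl with (propylamino)methyl, on a carbonyl carbon whose other neighbours are an amide-type nitrogen in a ring, gives in this assay a 1.8-fold lower number from compound 2 to compound 3 (0.26 log units; within the scatter). For the compounds shown here, this is the first single-place step in the set, and it shows that at this position a six-membered aromatic ring of carbon only can be exchanged for a group with no ring, one hydrogen-bond donor and one hydrogen-bond acceptor, without the number moving beyond the usual scatter of the read-out. Nothing available explains this outcome or connects it to any property of either group.

The step changes the ring and the nitrogen together, so the compounds shown leave open whether either change alone would give the same result. They also leave open how a longer chain on the amine, a tertiary amine such as dimethylamino, or a carboxylic acid at this same place would read in this assay, and whether any of these would move the number beyond the scatter.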